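Notes on a second methoxy group in the series

The source may hold more compounds than are shown below. What is called first, only, known or untested is meant among the compounds shown, and "the series" means these compounds.

Measured so far:
compound 1, `COc1ccc(-c2nnc(SC/C(=N/O)c3ccccc3)n2-c2ccccc2)cc1`: 73%
compound 2, `C=CCn1c(SC/C(=N/O)c2ccccc2)nnc1-c1ccc(OC)cc1`: 57%

In a functional assay on the whole organism (strain albino) for inhibition, with Rattus norvegicus as the target, read by paw edema, with a stated time of 5 h, at a dose of 0.28 mmol/kg by the oral route (a higher number here means more inhibition at the dose given (going by the name of the read-out), a lower number less inhibition), compound 1 gives 73%, the highest of the two numbers; compound 2 gives 57%, the step of a number 16 percentage points lower from compound 1 to compound 2 (beyond the scatter) being allyl in place of phenyl on an aromatic nitrogen. Compound 3, `COc1ccc(-c2nnc(SC/C(=N/O)c3ccccc3)n2-c2ccccc2)cc1OC`, differs from compound 1 by methoxy in place of hydrogen on an aromatic carbon, ortho to a methoxy group and meta to a large group, 4-methoxyphenyl to 3,4-dimethoxyphenyl. For the measured compounds named here, the only measured step concerns another part of the core and does not bear on this ring, so no guidance exists. The expected change is therefore a number 3 percentage points lower from compound 1 to compound 3 (within the scatter), nothing beyond the scatter. For compound 3 the estimate is 70%, ranging from 55% to 82%.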

Compound 3, a percentage reported as inhibition, in the whole organism at one dose (the size of the read-out at that dose, not a potency): 78%
For compound 3 the middle estimate is 8 percentage points below the measured one; low and high end bracket the measured number.
By their numbers in this assay, from the lowest: compound 2; then compounds 1 and 3 (each within the scatter of the next).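

Methoxy in place of hydrogen on an aromatic carbon, 4-methoxyphenyl to 3,4-dimethoxyphenyl, gives a number 5 percentage points higher from compound 1 to compound 3 (within the scatter) in this assay and is the first change shown on this ring. At this single dose, the place ortho to a methoxy group thus takes a second methoxy with no loss of inhibition beyond the scatter. Nothing measured here speaks to the reason for this result.

Open, going by these compounds, is whether a hydroxyl, a chlorine or a dimethylamino group at this place would move the number beyond the scatter. Also open, on these data alone, is whether the 3,4-dimethoxyphenyl change reads the same with allyl on the nitrogen, as in compound 2.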